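This account rests on a few compounds, and the source may have more. Where it says the series, first, only, none or still open, it means among the compounds named here.

Compound 1 `c1coc(-c2ccccc2NCC2=NCCN2)c1`: in a functional assay for activation of Alpha-1B adrenergic receptor (Homo sapiens), read by calcium flux (on this read-out higher numbers stand for an effect only at larger amounts of compound and lower numbers for an effect already at smaller amounts), compound 1 gives 6.31 nM.
Compound 2 `Cc1ncc(-c2ccccc2NCC2=NCCN2)o1`: in this assay compound 2 gives < 5020 nM, which is a limit of the assay and not a number.

For the measured compounds named here, compound 1 stands as the only compound with a numeric value in this assay; the one other value shown is a limit. Compound 3 `Cc1nc(-c2ccccc2NCC2=NCCN2)cs1` differs from compound 1 in 2-methyl-1,3-thiazol-4-yl in place of furan-2-yl on an aromatic carbon. Going by the values given here, the only measured step, a step that the limit leaves unreadable from compound 1 to compound 2, cannot be read for size because of the limit of < 5020 nM in this assay, at which 1 of the 2 values shown sits, so it offers no direction for the change to compound 3. Compound 3 is therefore expected, with wide uncertainty, to give 30 nM, between 5 nM and 300 nM, an estimated step of a 4.8-fold higher number from compound 1 to compound 3 (0.68 log units; beyond the scatter).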

Compound 3, half-maximal effective concentration: 69.2 nM
Estimate against measurement, compound 3: 2.3-fold (0.36 log units) below; low and high end bracket the measured number.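

For the compounds shown here, putting 2-methyl-1,3-thiazol-4-yl in place of furan-2-yl on this aromatic carbon gives the first readable step at this position in this assay: an 11-fold higher number from compound 1 to compound 3 (1.04 log units; beyond the scatter). The change therefore costs potency on this read-out, yet compound 3 still has a numeric value. The steps involving compound 2 cannot be read because its value is a limit and not a number: the limit of < 5020 nM in this assay, at which 1 of the 3 values shown sits.

The compounds shown do not separate the effect of the methyl group from that of the ring change. Going by these compounds, what an unsubstituted 1,3-thiazol-4-yl or a phenyl group would give at this place also stays open.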